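Chain Extension at the Aryl Substituent of Compound 1

The source may report more compounds than this note shows. Statements on the series, on what has been measured and on what is new or still open speak of the compounds shown alone.

Measured so far:
compound 1 `CCc1ccc(C(=O)/C=C/C(=O)O)cc1` — 21000 nM
compound 2 `Cc1ccc(C(=O)/C=C/C(=O)O)c(Cl)c1` — 27700 nM

In a functional assay on LS174T cells (Homo sapiens) for inhibition, read by MTT assay, with a stated time of 72 h (a higher number here means a weaker inhibitor, a lower number a stronger inhibitor), compound 1 gives 21000 nM. Compound 2 gives 27700 nM in this assay. Of the two numbers, compound 1 has the lower one, but the gap between compound 1 and compound 2 lies within the scatter of repeated measurements, so neither can be set above the other. No step between two measured compounds that differ in a single place has been shown, and nothing in the present numbers tells how a change at the saturated chain alters the read-out.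

Compound 3 `CCCCc1ccc(C(=O)/C=C/C(=O)O)cc1` is not yet measured in this assay. It differs from compound 1 as follows: ethyl in place of hydrogen on a saturated chain carbon, two bonds along the chain from an aromatic carbon. Among the compounds with values here, with no measured step to lean on, a modest change is expected, with some lean toward a lower number given that compound 1 already holds 21000 nM as the lower of the two measured values. The step from compound 1 to compound 3 in this assay is expected to be a 1.4-fold lower number from compound 1 to compound 3 (0.15 log units; within the scatter). For compound 3 the estimate in this assay is 15000 nM, within a range from 5000 nM to 50000 nM.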

Compound 3, half-maximal inhibitory concentration: 6740 nM
Estimate against measurement, compound 3: 2.2-fold (0.35 log units) above, within the range that was stated.
By their numbers in this assay, from the lowest: compound 3; then compounds 1 and 2 (each within the scatter of the next).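

In this assay the change of ethyl in place of hydrogen on a saturated chain carbon, two bonds along the chain from an aromatic carbon, gives a 3.1-fold lower number from compound 1 to compound 3 (0.49 log units; beyond the scatter) and this step lies beyond the scatter. Within the data shown here, it is the first change in a single place that can be read here, and it shows that the saturated chain is not a silent part of the structure: going from ethyl to butyl, with the rest of the core of compound 1 left as it is, moves the read-out to a lower number. No measurement shown here bears on what lies behind this result, and the step stands as an observation only.

One step at this position leaves open whether a longer chain such as hexyl would carry the number further down or turn it back up, and whether a branched chain such as isobutyl, or a butyl chain ending in a hydroxyl group or an amine, would read the same way. Also open, going by these compounds, are where propyl would fall on the path from ethyl to butyl and whether the same extension would give a step of like size on the core of compound 2.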